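A few compounds are considered here, and "the series" means these few. Any claim that something is new, unique, unknown or untested is made for them only; others in the source may bear on it.

Measured compounds:

Compound 1, `CC1(C)c2[nH]nc(NC(=O)c3ccccc3)c2CN1Cc1ccc(F)cc1`, in an assay on Sf21 cells for inhibition of high affinity nerve growth factor receptor (Homo sapiens), read by HTRF, with a stated time of 30 min, in the presence of a further agent that is not named here (a higher number here means a weaker inhibitor, a lower number a stronger inhibitor), compound 1 gives 1180 nM.

Compound 2, `CC1(C)c2[nH]nc(NC(=O)c3ccccc3)c2CN1Cc1cc(F)cc(F)c1`, in this assay compound 2 gives 190 nM.

Compound 2 holds the lowest number of the two, and its nearest neighbour is compound 1, separated by a step beyond the scatter: a 6.2-fold lower number from compound 1 to compound 2 (0.79 log units; beyond the scatter). That step is the only measured one, and it shows that the arrangement of the two fluorines on the phenyl bound to the saturated chain carbon on the ring nitrogen matters for this assay.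

Compound 3, `CC1(C)c2[nH]nc(NC(=O)c3ccccc3)c2CN1Cc1ccc(F)c(F)c1`, differs from compound 2 by 3,4-difluorophenyl in place of 3,5-difluorophenyl on a saturated chain carbon bound to an amine nitrogen in a ring. For the measured compounds named here, no measured pair covers this exact rearrangement. Going by the values given here, the one measured step bears on it only indirectly, since it too alters the fluorine pattern of that phenyl, and it was modest in size. Because compound 1 gives 1180 nM and compound 2 gives 190 nM, the new pattern in compound 3 is expected to land between them rather than beyond either. For compound 3 the expected step is a 2.1-fold higher number from compound 2 to compound 3 (0.32 log units; beyond the scatter), a weakening within a modest range. The estimate for compound 3 in this assay is 400 nM, with a range from 150 nM to 1100 nM.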

Compound 3, half-maximal inhibitory concentration: 680 nM
For compound 3 the middle estimate is 1.7-fold (0.23 log units) below the measured one, and the stated range covers the measured number.
By their numbers in this assay, from the lowest: compound 2; then compounds 3 and 1 (each within the scatter of the next).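

In this assay the result separates two isomers: with the same atoms joined differently, 3,4-difluorophenyl in place of 3,5-difluorophenyl gives a 3.6-fold higher number from compound 2 to compound 3 (0.55 log units; beyond the scatter) and leaves compound 2 clear of compound 3, so the placing of the fluorines, and not their number alone, matters on this ring. Fluoro in place of hydrogen on an aromatic carbon gives a 1.7-fold lower number from compound 1 to compound 3 (0.24 log units; within the scatter) and does not separate the two compounds, so a second fluorine does not by itself reproduce the standing of compound 2. Nothing available here explains the difference between the two difluorophenyl isomers.

The compounds shown leave open whether the advantage of the 3,5-pattern belongs to fluorine at all, as 3,5-dichlorophenyl, 3,5-dimethoxyphenyl, or a single-fluorine 3-fluorophenyl would be needed to tell. They also leave open whether the ranking of these benzyl groups holds when the benzamide carries another group, such as a piperazine or a carboxylic acid, since the benzoyl part and the rest of the core are the same throughout.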